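The source may hold more compounds than are shown below. What is called first, only, known or untested is meant among the compounds shown, and "the series" means these compounds.

Compound 1 `COc1cc(OC)c(C(=O)/C=C/c2ccccc2OC)c(OC)c1` and compound 2 `COc1cc(OC)c(C(=O)/C=C/c2ccccc2SC)c(OC)c1` share one core, and compound 3 `COc1cc(OC)c(C(=O)/C=C/c2ccc(F)cc2)c(OC)c1` is the member still to be measured. In a functional assay on Caco-2 cells (Homo sapiens) for cytotoxicity, with a stated time of 48 h (on this read-out lower numbers stand for stronger inhibition and higher numbers for weaker inhibition), compound 1 gives 4500 nM, the lowest of the two numbers in hand, and compound 2 gives 8800 nM. Within the data shown here, the only measured step, a 2.0-fold higher number from compound 1 to compound 2 (0.29 log units; within the scatter), exchanges one group on an aromatic carbon and stays within the scatter. The change to compound 3 is of another kind: 4-fluorophenyl in place of 2-methoxyphenyl on a double-bonded chain carbon bound to a double-bonded chain carbon. Among the measured compounds shown here, no measured step exchanges the whole aryl group, so the sole guidance is that the one variation tried on that ring, a 2.0-fold higher number from compound 1 to compound 2 (0.29 log units; within the scatter), moved nothing beyond the scatter; a change that leaves no hydrogen-bond acceptor on the ring is untested. The expected step is a 1.3-fold higher number from compound 1 to compound 3 (0.12 log units; within the scatter), which is to say none beyond the scatter. Compound 3 is expected to give about 6000 nM in this assay, within a range from 2500 nM to 15000 nM.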

Compound 3, half-maximal inhibitory concentration: 5500 nM
For compound 3 the middle estimate is 1.1-fold (0.04 log units) above the measured one; measured number inside the range.
By their numbers in this assay, from the lowest: compounds 1, 3 and 2 (each within the scatter of the next).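

In this assay the exchange of the whole aryl group on a double-bonded chain carbon bound to a double-bonded chain carbon stays within the scatter, both against 2-methoxyphenyl (a 1.2-fold higher number from compound 1 to compound 3 (0.09 log units; within the scatter)) and against 2-(methylsulfanyl)phenyl (a 1.6-fold lower number from compound 2 to compound 3 (0.20 log units; within the scatter)). Among compounds 1, 2 and 3, the read-out therefore does not separate these aryl groups, and 4-fluorophenyl, with 0 hydrogen-bond acceptors, reads the same as 2-methoxyphenyl, with 1. No measurement is available that would explain this result. As far as these compounds go, whether an aryl group bearing an amine or a carboxylic acid would give a step beyond the scatter remains open. Also open, from the compounds shown here alone, is what the methoxy groups on the shared core contribute, since all three compounds carry them unchanged.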